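Methoxy on the triazole phenyl of compound 2

The compounds below may be only part of what the source reports. "The series", "measured", "known", "first", "only" and "open" are said of these compounds alone.

Measured in a functional assay on HL-60 cells (Homo sapiens) for cytotoxicity, read by MTT assay, with a stated time of 4 days; on this read-out lower numbers stand for stronger inhibition and higher numbers for weaker inhibition:
- compound 1 `Cc1ccc(S(=O)(=O)Oc2ccc3c(c2C)[C@H](Cn2cc(-c4ccccc4)nn2)[C@@]24CC(=O)[C@@](C)(CC[C@@H]32)C4)cc1` gives > 20000 nM, which is a limit of this assay and not a number.
- compound 2 `C=C1C(=O)[C@]23C[C@@]1(O)CC[C@H]2c1ccc(O)c(C)c1[C@@H]3Cn1cc(-c2ccccc2)nn1` gives 750 nM.
- compound 3 `C=C1C[C@]23C[C@@]1(O)CC[C@H]2c1cc(Br)c(O)c(C)c1[C@@H]3Cn1cc(-c2ccc(F)cc2)nn1` gives 6600 nM.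

Of the two numbers recorded, compound 2 holds the lower one; compound 3 sits higher by a margin beyond the usual scatter. Compound 1 contributes only a limit, the line being (the limit of > 20000 nM in this assay, at which 1 of the 3 values shown sits), so it gives no number to rank.

Compound 4 `C=C1C(=O)[C@]23C[C@@]1(O)CC[C@H]2c1ccc(O)c(C)c1[C@@H]3Cn1cc(-c2ccc(OC)cc2)nn1` has not yet been measured. It differs from compound 2 in one place: methoxy in place of hydrogen on an aromatic carbon, para to a large group; cut one bond further out, phenyl becomes 4-methoxyphenyl. Among the measured compounds shown here, no pair of measured compounds differing only in this way exists, so the size of the step cannot be read from the data. Compounds 2 and 3 differ in several places at once and do not isolate the phenyl substitution.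

The expectation is therefore a step of a 1.2-fold higher number from compound 2 to compound 4 (0.08 log units; within the scatter) in this assay, most likely within the scatter, direction uncertain. Compound 4 is estimated at 900 nM, with a range from 300 nM to 3000 nM.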

Compound 4, half-maximal inhibitory concentration: 1150 nM
The estimate for compound 4 lay 1.3-fold (0.11 log units) below the measured number; measured number inside the range.
By their numbers in this assay, from the lowest: compounds 2 and 4 (each within the scatter of the next); then compound 3. At a limit, above all of these: compound 1.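

In this assay, among the compounds shown here, the change from phenyl to 4-methoxyphenyl gives a 1.5-fold higher number from compound 2 to compound 4 (0.19 log units; within the scatter), the first step that isolates a single place, since the earlier compounds differ from one another in several places at once. At this position, on an aromatic carbon of a six-membered aromatic ring of carbon only and para to a large group, the shared core therefore accepts a methoxy, with its 2 heavy atoms and 1 hydrogen-bond acceptor, and the cytotoxicity read-out stays within the scatter. No measured property shown here bears on this step.

For the compounds shown here, whether this tolerance extends to other groups at the same place remains open: a hydroxyl, an amine, a carboxylic acid or a longer chain such as butoxy could each behave differently from methoxy, so the single step gives no trend across substituents. Going by these compounds, it also remains open whether methoxy at this position would give a step of similar size on the core of compound 3, which carries a different arrangement of groups elsewhere.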